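The source may hold more compounds than are shown below. What is called first, only, known or untested is meant among the compounds shown, and "the series" means these compounds.

Measured so far in a functional assay on SK-MEL-28 cells (Homo sapiens) for inhibition, read by sulforhodamine B assay, with a stated time of 48 h; a higher number here means a weaker inhibitor of growth, a lower number a stronger inhibitor of growth:

compound 1, `COc1cc(-c2cc(/C=C/C(=O)c3ccc(N)cc3)[nH]n2)cc(OC)c1OC`: 1860 nM
compound 2, `COc1ccc(-c2cc(/C=C/C(=O)c3ccc(OC)c(OC)c3)[nH]n2)cc1`: 1650 nM
compound 3, `COc1cc(-c2cc(/C=C/C(=O)c3ccc(Cl)c(Cl)c3)[nH]n2)cc(OC)c1OC`: 18500 nM

Compound 1 stands second highest of the three numbers. Its nearest neighbour is compound 2, whose value sits within the usual scatter of that of compound 1, so no order between these two can be read. Its furthest neighbour is compound 3: a 9.9-fold higher number from compound 1 to compound 3 (1.00 log units; beyond the scatter), a modest step and the only one in the set.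

Compound 4, `COc1ccc(-c2cc(/C=C/C(=O)c3ccc(N)cc3)[nH]n2)cc1OC`, keeps the side of compound 1 that carries the carbonyl carbon and the aminophenyl group unchanged. The difference from compound 1 is hydrogen in place of methoxy on an aromatic carbon.

Among the compounds with values here, no measured step touches the ring bearing the methoxy groups. Within the data shown here, the single step, from compound 1 to compound 3, changes the group on the carbonyl carbon and so does not bear on the present change. Compounds 1 and 2 differ on both rings at once, and their two values are within the scatter of each other; that pair shows no more than that. With nothing to push in either direction, the expectation is a step within the scatter: a 1.1-fold higher number from compound 1 to compound 4 (0.03 log units; within the scatter). The estimated value for compound 4 is 2000 nM, with a range from 900 nM to 4500 nM.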

Compound 4, concentration for 50% growth inhibition: 2140 nM
Estimate against measurement, compound 4: 1.1-fold (0.03 log units) below, within the range that was stated.
By their numbers in this assay, from the lowest: compounds 2, 1 and 4 (each within the scatter of the next); then compound 3.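

In this assay, within the data shown here, hydrogen in place of methoxy, on an aromatic carbon ortho to a methoxy group and meta to a large group, gives a 1.2-fold higher number from compound 1 to compound 4 (0.06 log units; within the scatter) as the first measured step on the ring bearing the methoxy groups. Among these compounds, with the aminophenyl side held fixed, this methoxy group can therefore be lost with no readable change in growth inhibition, whereas the change on the carbonyl carbon, a 9.9-fold higher number from compound 1 to compound 3 (1.00 log units; beyond the scatter) in the same assay, remains the only step beyond the scatter. No measurement on this position is at hand that would account for the result.

Open, going by these compounds, is whether other groups at this position, such as hydroxy, ethoxy or a chlorine atom, would stay as close to compound 1 as hydrogen does, or whether any of them would give a step beyond the scatter. Also open, on these data alone, is whether the same loss of methoxy would read the same on the 3,4-dichlorophenyl side of compound 3, where the value starts from a much weaker level.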